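The compounds below may be only part of what the source reports. "The series", "measured", "known", "first", "only" and "open" are said of these compounds alone.

Measured in a functional assay on MCF7 cells (Homo sapiens) for antiproliferative activity, read by MTT assay, with a stated time of 24 h; on this read-out higher numbers stand for an effect only at larger amounts of compound and lower numbers for an effect already at smaller amounts:
- compound 1 `CSc1ccc(/C(=N\O)c2cccc3ccccc23)cc1`: 18000 nM
- compound 2 `CCOC(=O)CO/N=C(\c1ccc(SC)cc1)c1cccc2ccccc12`: 30000 nM
- compound 3 `CSc1ccc(/C(=N\OCCCCN2CCCCC2)c2cccc3ccccc23)cc1`: 8000 nM

Compound 2 stands at the high end of these numbers together with compound 1, as a 1.7-fold higher number from compound 1 to compound 2 (0.22 log units; within the scatter) shows. Compound 3 lies lower than both.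

The step of interest leads to the unmeasured compound 4 `CSc1ccc(/C(=N\OCCCCN2CCCC2)c2cccc3ccccc23)cc1`. The change is 3-(pyrrolidin-1-yl)propyl in place of ethoxycarbonyl on a saturated chain carbon bound to an oxygen on an unsaturated carbon. Read one bond further out, this is (ethoxycarbonyl)methyl to 4-(pyrrolidin-1-yl)butyl.

The closest measured change is a 3.8-fold lower number from compound 2 to compound 3 (0.57 log units; beyond the scatter), which puts 3-(piperidin-1-yl)propyl at the same place. A second relevant step is a 2.3-fold lower number from compound 1 to compound 3 (0.35 log units; beyond the scatter), where 4-(piperidin-1-yl)butyl replaces hydrogen on an oxygen. Both are modest, and both point to a lower number with a ring-bearing chain of this kind. Going by the values given here, no measured compound carries the five-membered ring, so the read-across from compound 3 remains uncertain, and the range is kept wide.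

A modest step to a lower number is therefore expected in this assay, estimated as a 3.3-fold lower number from compound 2 to compound 4 (0.52 log units; beyond the scatter). The expected value for compound 4 is 9000 nM, with an estimated range of 4000 nM to 20000 nM.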

Compound 4, half-maximal effective concentration: > 50000 nM
Compound 4: only a limit was reported; the forecaster's own chance of this, stated with the estimate: 3%; at least 5.5-fold (0.74 log units) between middle value and limit.
By their numbers in this assay, from the lowest: compound 3; then compounds 1 and 2 (each within the scatter of the next). At a limit, above all of these: compound 4.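

In this assay compound 4 is reported only as a limit, not as a number: the limit of > 50000 nM in this assay, at which 1 of the 4 values shown sits.

Going by these compounds alone, the ring change alone, pyrrolidin-1-yl in place of piperidin-1-yl on a saturated chain carbon, four bonds along the chain from an oxygen, gives an at least 6.2-fold higher number from compound 3 to compound 4 (0.79 log units; beyond the scatter), so the outcome at this chain end depends on which ring is present, something the earlier compounds could not show. A butyl chain with a ring at its end thus does not by itself give a lower number: an at least 2.7-fold higher number from compound 1 to compound 4 (0.44 log units; beyond the scatter) runs against a 2.3-fold lower number from compound 1 to compound 3 (0.35 log units; beyond the scatter), while an at least 1.6-fold higher number from compound 2 to compound 4 (0.22 log units; that floor lies within the scatter) leaves the order of that pair unsettled.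

As far as these compounds go, it remains open whether an open-chain amine such as diethylamino or a morpholine ring at the same chain end would follow compound 3 or compound 4. Also open, from the compounds shown here alone, is whether piperidin-1-yl on a shorter propyl chain or a longer hexyl chain would keep the number of compound 3, and how far the ring change truly reaches beyond the limit of compound 4.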